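Replacing an aryl group with an arylamino on the carbonyl

The source may report more compounds than this note shows. Statements on the series, on what has been measured and on what is new or still open speak of the compounds shown alone.

Measured so far:
- compound 1, `CCc1ccccc1C(=O)OC(CCN(C)C)c1ccc(Cl)cc1`: 128%
- compound 2, `CN(C)CCC(NC(=O)c1ccc(C(F)(F)F)cc1)c1ccc(Cl)cc1`: 115%

Both compounds were tested in an assay on NIH3T3 cells with Urotensin-2 receptor (Homo sapiens) as the target; a lower number here means a smaller maximal response, a higher number a larger maximal response. In this assay compound 1 gives 128%, the higher of the two numbers. Compound 2 gives 115%, which lies beyond the usual scatter below compound 1. The two compounds differ in more than one place, so their values show only that both reach a maximal response above the reference, with compound 1 ahead.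

Compound 3, `Cc1ccccc1NC(=O)OC(CCN(C)C)c1ccc(Cl)cc1`, has not yet been measured. It keeps the core of compound 1 and differs in a single spot: (2-methylphenyl)amino in place of 2-ethylphenyl on a carbonyl carbon. The entering group brings one hydrogen-bond donor where the leaving group had none. For the measured compounds named here, no measured pair shows a change of this kind, so the size of the step is open. A modest move downwards is expected, possibly still within the scatter, because compound 2 with its amide link gives 115%. For compound 3 the estimated value is 115%, with a range from 95% to 135%. This amounts to an expected step of a number 13 percentage points lower from compound 1 to compound 3 (beyond the scatter).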

Compound 3, largest response reached (reported as efficacy), in percent of the reference or control that the assay uses: 176%
Compound 3: middle estimate off by 61 percentage points, on the low side; the measured number lies above the stated range.
By their numbers in this assay, from the lowest: compound 2; then compound 1; then compound 3.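

In this assay, the group on the carbonyl carbon proves to be a sensitive place in the molecule: putting (2-methylphenyl)amino in place of 2-ethylphenyl gives a number 48 percentage points higher from compound 1 to compound 3 (beyond the scatter), a large step. The leaving and entering groups have the same number of heavy atoms and each carries one six-membered aromatic ring, so a large change in maximal response here does not require a larger group. The swap is nevertheless a double one, since it adds a nitrogen with its hydrogen-bond donor between the ring and the carbonyl carbon and also exchanges ethyl for methyl on the ring.

Nothing available here explains why the maximal response rises, so the step stands as an observation without a known cause. The compounds shown also leave the two parts of the swap unseparated: (2-ethylphenyl)amino on the same carbonyl carbon would keep the ethyl and add only the nitrogen, while 2-methylphenyl there would keep the direct ring attachment and change only the ethyl to methyl.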